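The source may report more compounds than this note shows. Statements on the series, on what has been measured and on what is new or still open speak of the compounds shown alone.

Measured in a functional assay on the whole organism with Mus musculus as the target, in the maximal electroshock model (on this read-out higher numbers stand for an effect only at larger amounts of compound and lower numbers for an effect already at smaller amounts), so far:
- compound 1 `CNC(=O)[C@@H](CO)NCc1ccc(OCc2ccccc2)cc1` gives 22.8 mg/kg
- compound 2 `CNC(=O)[C@@H](CO)NCc1ccc(OCc2cccc(C)c2)cc1` gives 30.6 mg/kg
- compound 3 `CNC(=O)[C@@H](CO)NCc1ccc(OCc2cccc(C(F)(F)F)c2)cc1` gives 13.1 mg/kg

Compound 2 and compound 1 sit together at the high-number end of this short series, as shown by a 1.3-fold higher number from compound 1 to compound 2 (0.13 log units; within the scatter). Compound 3 is set apart from compound 2 by a 2.3-fold lower number from compound 2 to compound 3 (0.37 log units; beyond the scatter), a modest step.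

Compound 4 `CNC(=O)[C@@H](CO)NCc1ccc(OCc2ccccc2F)cc1` has not been measured. Its difference from compound 2 is 2-fluorophenyl in place of 3-methylphenyl on a saturated chain carbon bound to an oxygen on an aromatic ring.

Within the data shown here, no measured compound carries fluorine on this ring, so no step tests the entering group directly. Among the measured compounds shown here, two steps bear on the change indirectly. Compound 2 loses its methyl group, and the methyl step, a 1.3-fold higher number from compound 1 to compound 2 (0.13 log units; within the scatter), stayed small. The only other replacement of that methyl, a 2.3-fold lower number from compound 2 to compound 3 (0.37 log units; beyond the scatter), also stayed modest and pointed to a lower number.

For the measured compounds named here, a small shift towards lower numbers is therefore expected in this assay, with no large step anticipated. The estimated step is a 1.5-fold lower number from compound 2 to compound 4 (0.18 log units; within the scatter). The expected value for compound 4 is 20 mg/kg, with an estimated range from 9 mg/kg to 42 mg/kg.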

Compound 4, dose for half-maximal effect: 19.8 mg/kg
Beside the measured number, compound 4's estimate is 1.0-fold (0.00 log units) above it, within the range that was stated.
By their numbers in this assay, from the lowest: compounds 3, 4, 1 and 2 (each within the scatter of the next, the first and the last beyond it).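

Among these compounds, compound 4 is the first with fluorine on this ring, and in this assay adding fluoro to this ring gives a 1.2-fold lower number from compound 1 to compound 4 (0.06 log units; within the scatter) and so cannot be told from the unsubstituted compound. The exchange of 3-methylbenzyl for 2-fluorobenzyl gives a 1.5-fold lower number from compound 2 to compound 4 (0.19 log units; within the scatter) and also stays unresolved, which means that a substituent named at the 2-position of the phenyl ring, not only the 3-substituted rings seen earlier, is compatible with a number in the same range in this assay. No measurement on hand accounts for these small steps, so they are recorded here without any explanation.

Fluoro and methyl are each read here with a single ring placement, so the effect of the group cannot be separated from the effect of where it is named on the ring. On these data alone, it also stays open whether a larger change on this ring, such as an amine, a carboxylic acid or a nitrile, would produce a step beyond the scatter in this assay or whether this ring accepts those groups as it accepts fluoro and methyl.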